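Cytotoxicity in RD cells: tert-butoxycarbonyl to benzoyl on the shared core

The compounds below may be only part of what the source reports. "The series", "measured", "known", "first", "only" and "open" are said of these compounds alone.

Compound 2 `CC(=O)c1cccc(Nc2nc(-c3sc(NC(=O)OC(C)(C)C)nc3C)cs2)c1` holds the highest of the two numbers in an ADME assay on RD cells (Homo sapiens) for cytotoxicity, read by microscopy (on this read-out lower numbers stand for higher toxicity in this test and higher numbers for lower toxicity in this test), with 101000 nM. Compound 1 `CC(=O)Nc1nc(C)c(-c2c[nH]c(Nc3cccc(C(C)=O)c3)n2)s1` is its nearest neighbour; in this assay compound 1 gives 64200 nM, a gap that lies within the scatter, so the two are read as alike. For compound 3 `CC(=O)Nc1cccc(NC(=S)Nc2cccc(C(C)=O)c2)c1` the outcome in this assay is "not determined" (no result reported), so no result was obtained. Compound 4 `CC(=O)c1cccc(Nc2nc(-c3sc(NC(=O)c4ccccc4)nc3C)cs2)c1` differs from compound 2 by phenyl in place of tert-butoxy on a carbonyl carbon. For the measured compounds named here, no step between measured compounds is available for this change. The expectation is a step of no more than the scatter, in no fixed direction, so that a 1.3-fold lower number from compound 2 to compound 4 (0.10 log units; within the scatter) is estimated as small. Compound 4 is therefore expected to give 80000 nM in this assay, within a range from 30000 nM to 200000 nM.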

Compound 4, half-maximal cytotoxic concentration: 11800 nM
Compound 4: middle estimate off by 6.8-fold (0.83 log units), on the high side; measured number below the stated range.
By their numbers in this assay, from the lowest: compound 4; then compounds 1 and 2 (each within the scatter of the next).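

In this assay, phenyl in place of tert-butoxy on a carbonyl carbon gives an 8.6-fold lower number from compound 2 to compound 4 (0.93 log units; beyond the scatter), so the group at this position does change the read-out, here towards higher toxicity in this test. Before this pair, no step between compounds differing in one place was available. Nothing shown gives a reason for this step.

On these data alone, whether the step follows from the entering aromatic ring or from the departing tert-butoxy stays open with one pair. A cyclohexyl, a methyl or an amine on the same carbonyl carbon would help separate the two.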